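Adding Chlorine to the Core of Compound 1

The compounds below may be only part of what the source reports. "The series", "measured", "known", "first", "only" and "open" are said of these compounds alone.

Among the compounds with values here, compound 1 `O=c1cc(CSC(=S)N2CCCC2)oc2ccccc12` is the only member of this small set with a definite number: in a functional assay on LM7 cells (Homo sapiens) for antiproliferative activity, read by MTT assay, with a stated time of 72 h (on this read-out lower numbers stand for stronger inhibition and higher numbers for weaker inhibition), compound 1 gives 40000 nM. Compound 2 `O=c1cc(CSC(=S)N2CCCC2)oc2cc(Cl)ccc12` reaches only a limit of the assay, > 25000 nM. Compound 3 `O=c1cc(CSC(=S)N2CCOCC2)oc2cc(Cl)ccc12` likewise sits at a limit, > 25000 nM. Because of the limit of > 25000 nM in this assay, at which 2 of the 3 values shown sit, the steps a step that the limit leaves unreadable from compound 1 to compound 2 and a step that the two limits leave unreadable from compound 2 to compound 3 cannot be sized. Compound 4 `O=c1c(Cl)c(CSC(=S)N2CCCC2)oc2ccccc12` carries the change (chloro in place of hydrogen on an aromatic carbon). Within the data shown here, no measured step touches this position, and the two measured steps give no readable size, so nothing points to a move beyond the scatter in this assay. A step of no change at the digits printed from compound 1 to compound 4 (within the scatter) is therefore expected, placing compound 4 at an estimated 40000 nM, within 10000 nM to 160000 nM.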

Compound 4, half-maximal inhibitory concentration: 1900 nM
Beside the measured number, compound 4's estimate is 21-fold (1.32 log units) above it; the whole stated range lies above it.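

In this assay, within the data shown here, chloro on this carbon, two atoms from the ring oxygen, gives a 21-fold lower number from compound 1 to compound 4 (1.32 log units; beyond the scatter) and so supplies the first readable step in the set. It shows that one added chlorine atom can matter on the core of compound 1 when it sits here. The same change elsewhere on the core, in compound 2, has no size that can be read, and the step from compound 2 to compound 3 is equally unreadable: the limit of > 25000 nM in this assay, at which 2 of the 4 values shown sit.

Whether the gain is special to chloro stays open: fluoro, methyl or an amine at this carbon is not among the compounds shown. Also open, from the compounds shown here alone, is whether morpholin-4-yl in place of pyrrolidin-1-yl would keep the gain in compound 4.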